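A few compounds are considered here, and "the series" means these few. Any claim that something is new, unique, unknown or untested is made for them only; others in the source may bear on it.

Compound 1 `CCCSc1nc(N/N=C/c2ccc(Cl)cc2)c2nnn(Cc3ccccc3)c2n1` has no measurable number on this read-out: in a functional assay on MCF7 cells (Homo sapiens) for antiproliferative activity, read by MTT assay, with a stated time of 72 h (on this read-out lower numbers stand for stronger inhibition and higher numbers for weaker inhibition), compound 1 gives > 64000 nM, which is a limit of the assay rather than a value. This is where compound 1 stands, (the limit of > 64000 nM in this assay, at which 1 of the 2 values shown sits). Among the measured compounds shown here, the only other compound with a result, compound 2 `C#CCSc1nc(N/N=C/c2cc(OC)c(OC)c(OC)c2)c2nnn(Cc3ccccc3)c2n1`, differs from compound 1 in more than one place; in this assay compound 2 gives 17000 nM. No two measured compounds differ in a single place, so no single step has been recorded, and no cause for either value can be drawn from the data.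

Compound 3 `CCCSc1nc(N/N=C(\C)c2ccccc2O)c2nnn(Cc3ccccc3)c2n1` remains to be measured. It differs from compound 1 in one place: a group of 10 heavy atoms (8 carbon, 1 nitrogen, 1 oxygen; one six-membered aromatic ring of carbon only) in place of a group of 9 heavy atoms (7 carbon, 1 nitrogen, 1 chlorine; one six-membered aromatic ring of carbon only), on a nitrogen on an aromatic ring. The entering group carries one hydrogen-bond donor and two hydrogen-bond acceptors where the leaving group carried none and one. With compound 1 sitting at the limit, the step is expected to be small, possibly none beyond the scatter, with only a modest chance of a gain. Compound 3 is expected to give 60000 nM, within 20000 nM to 150000 nM. The expected step is an at least 1.0-fold lower number from compound 1 to compound 3 (0.02 log units; that floor lies within the scatter).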

Compound 3, half-maximal inhibitory concentration: 11000 nM
Compound 3: the middle estimate sits 5.5-fold (0.74 log units) above what was measured, and the stated range ends above it.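

Among the compounds shown here, the result gives the first single step on record: on a nitrogen on an aromatic ring whose other neighbours are aromatic carbon, the exchange of one group for the other goes with an at least 5.8-fold lower number from compound 1 to compound 3 (0.76 log units; beyond the scatter) in this assay. This shows that the read-out is not indifferent to the group at this place, although the step cannot be pinned on any one feature of the exchange, since the entering group differs from the leaving group at once in its heavy atoms, in carrying oxygen where the other carried chlorine, and in its hydrogen-bond donor. The step has a floor but no known full size, because compound 1 stands at a limit and not at a number: the limit of > 64000 nM in this assay, at which 1 of the 3 values shown sits.

The compounds shown leave open which part of the entering group goes with the step, as no compound here changes only the chlorine or only the oxygen. They also leave open how an amine or a carboxylic acid on the aromatic ring of this group would read in this assay, and whether the step would hold with a longer chain in the rest of the molecule.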